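Acetyl to dimethylamino on the pendant phenyl ring

The compounds below may be only part of what the source reports. "The series", "measured", "known", "first", "only" and "open" are said of these compounds alone.

Two compounds of this series have numbers in a functional assay on RPMI8266 cells (Homo sapiens) for cytotoxicity, read by sulforhodamine B assay, with a stated time of 48 h, tested at 0.01 uM (a lower number here means a stronger effect, a higher number a weaker effect of the compound at the concentration tested), so far. Compound 1 `COc1cc(C)cc(-c2c(-c3ccnc(-c4ccc(C(C)=O)cc4)c3)cnn2CC#N)c1` gives 94% in this assay, which is the lowest of the two numbers; the nearest is compound 2 `COc1cc(C)cc(-c2nn(CC#N)cc2-c2ccnc(-c3ccc(N(C)C)cc3)c2)c1`, which in this assay gives 110%, a gap beyond the scatter. Both numbers sit close to no effect at the concentration used.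

Compound 3 `COc1cc(C)cc(-c2c(-c3ccnc(-c4ccc(N(C)C)cc4)c3)cnn2CC#N)c1` has not yet been measured in this assay. It differs from compound 1 in one place: dimethylamino in place of acetyl on an aromatic carbon

Going by the values given here, no step between measured compounds that differ in one place is known, so there is nothing to calibrate this change against. Given that compound 1 itself gives 94%, little room remains for a weaker read-out, and the expected step from compound 1 to compound 3 is a number 6 percentage points higher from compound 1 to compound 3 (within the scatter), which stays within the scatter. Compound 3 is therefore estimated at 100% in this assay, with a range from 85% to 115%.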

Compound 3, a percentage reported as activity, at one concentration (the size of the read-out at that concentration, not a potency): 78%
For compound 3 the middle estimate is 22 percentage points above the measured one; measured number outside the range, below it.
By their numbers in this assay, from the lowest: compound 3; then compound 1; then compound 2.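

Dimethylamino in place of acetyl on the aromatic carbon para to a large group gives the first one-place step of the series in this assay: a number 16 percentage points lower from compound 1 to compound 3 (beyond the scatter). This position is therefore not silent at the concentration tested, since the group held there changes the read-out, towards a stronger effect, even though the step is modest and describes the size of the read-out at one concentration, not a potency. No measurement available here bears on the origin of this step.

From the compounds shown here alone, with a single step, it remains open whether the result reflects the loss of acetyl or the arrival of dimethylamino. A primary amine or a carboxylic acid on the same carbon would help separate the two, and readings at higher concentrations would show whether the step persists there.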